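Swapping Ethylsulfanyl for (Pentan-3-yl)oxy on a Carbonyl Carbon

A few compounds are considered here, and "the series" means these few. Any claim that something is new, unique, unknown or untested is made for them only; others in the source may bear on it.

In an assay on membranes from HeLa cells for displacement of a labelled ligand from adenosine receptor A3 (Homo sapiens), read by scintillation counting, with a stated time of 180 min, tested at 1 uM (on this read-out lower numbers stand for less inhibition and higher numbers for more inhibition at the one concentration tested (going by the name of the read-out)), compound 2 `CCSC(=O)C1=C(C)NC(=O)NC1c1ccoc1` gives 1%, and compound 1 `CCCC(=O)C1=C(C)NC(=O)NC1c1ccoc1` gives 2%; the two values lie within the scatter of each other, so neither stands apart. The step of a number 1 percentage points lower from compound 1 to compound 2 (within the scatter) accompanied ethylsulfanyl in place of propyl on a carbonyl carbon. Compound 3 `CCC(CC)OC(=O)C1=C(C)NC(=O)NC1c1ccoc1` differs from compound 2 by (pentan-3-yl)oxy in place of ethylsulfanyl on a carbonyl carbon. Among the measured compounds shown here, the only step that bears on this change, from compound 1 to compound 2, was within the scatter, so no step beyond the scatter is expected in this assay. Compound 3 is therefore estimated at 2%, between -8% and 12%. This estimate means an expected step of a number 1 percentage points higher from compound 2 to compound 3 (within the scatter).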

Compound 3, a percentage reported as inhibition, at one concentration (the size of the read-out at that concentration, not a potency): 5%
For compound 3 the middle estimate is 3 percentage points below the measured one, and the stated range covers the measured number.
By their numbers in this assay, from the lowest: compounds 2, 1 and 3 (each within the scatter of the next).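

In this assay, (pentan-3-yl)oxy on the carbonyl carbon went with a number 4 percentage points higher from compound 2 to compound 3 (within the scatter), and in place of propyl it went with a number 3 percentage points higher from compound 1 to compound 3 (within the scatter). A group joined through oxygen thus stands level with those joined through carbon and sulfur, so none of the three linking atoms sets its compound apart at this position. No measurement is at hand that would explain this result. On these data alone, whether an amine or a longer chain on this carbonyl carbon would move the number beyond the scatter stays open, as does the effect of any change elsewhere on the shared core.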